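From piperidin-1-yl to dimethylamino on a shared core

The source may hold more compounds than are shown below. What is called first, only, known or untested is meant among the compounds shown, and "the series" means these compounds.

Compound 1 `Cc1c(C)c2c(c(C)c1O)C(CN1CCCCC1)C(C)(C)O2`: 400 nM
Compound 2 `Cc1c(C)c2c(c(C)c1O)C(CN1CCN(c3ncccn3)CC1)C(C)(C)O2`: 400 nM
Compound 3 `Cc1c(C)c2c(c(C)c1O)CCC(C)(CC[N+](C)(C)C)O2`: 2000 nM

In a functional assay (brain) for inhibition, with Rattus norvegicus as the target (on this read-out higher numbers stand for weaker inhibition and lower numbers for stronger inhibition), compound 1 gives 400 nM and stands level with compound 2 at 400 nM as the lowest of the three numbers, while compound 3 reads higher at 2000 nM on the same scale. Compound 4 `Cc1c(C)c2c(c(C)c1O)C(CN(C)C)C(C)(C)O2` has not yet been measured. Its change from compound 1 is dimethylamino in place of piperidin-1-yl on a saturated chain carbon bound to a saturated ring carbon and reads in words as dimethylamino in place of piperidin-1-yl on a saturated chain carbon bound to a saturated ring carbon. Going by the values given here, no measured pair differs in one place alone, so the data offer no direct guide. No shift beyond the scatter is expected in this assay for this change. The estimated step of a 1.3-fold higher number from compound 1 to compound 4 (0.10 log units; within the scatter) is small. For compound 4 the expected value is 500 nM within a range of 150 nM to 1500 nM by this estimate.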

Compound 4, half-maximal inhibitory concentration: 700 nM
Estimate against measurement, compound 4: 1.4-fold (0.15 log units) below; measured number inside the range.
By their numbers in this assay, from the lowest: compounds 1, 2 and 4 (each within the scatter of the next); then compound 3.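

In this assay, going by these compounds alone, dimethylamino in place of piperidin-1-yl on a saturated chain carbon bound to a saturated ring carbon gives a 1.8-fold higher number from compound 1 to compound 4 (0.24 log units; within the scatter) and is the first change here that can be read in one place. At this position, the six-membered non-aromatic ring of piperidin-1-yl can therefore give way to an open dimethylamino group without a shift beyond the scatter. No evidence given here bears on this result.

The compounds shown leave open whether morpholin-4-yl or a primary amine would read the same at this position. They also leave open what a longer chain carrying the dimethylamino group would do.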